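This account rests on a few compounds, and the source may have more. Where it says the series, first, only, none or still open, it means among the compounds named here.

Compound 1, `O=Cc1cn(-c2ccccc2)nc1-c1ccc(Cl)cc1`: in a functional assay on A549 cells (Homo sapiens) for antiproliferative activity, read by MTT assay, with a stated time of 48 h (on this read-out higher numbers stand for weaker inhibition and lower numbers for stronger inhibition), compound 1 gives 29500 nM.
Compound 2, `Fc1ccc2[nH]c(-c3cn(-c4ccccc4)nc3-c3ccccc3)nc2c1`: in this assay compound 2 gives 1720 nM.

Of these two numbers, compound 2 holds the lower one; compound 1 stands well above it, a gap that lies beyond the usual scatter of repeated measurements. The two compounds differ in more than one place, so nothing can be said about which part of compound 2 accounts for the difference.

Compound 3, `Brc1ccc2[nH]c(-c3cn(-c4ccccc4)nc3-c3ccccc3)nc2c1`, has not yet been measured in this assay. It keeps the whole framework of compound 2 and changes one substituent: bromo in place of fluoro on an aromatic carbon. Among the compounds with values here, no pair of measured compounds shows the effect of a single change of this kind, so there is no measured step to lean on. Without such a step, the expectation is that the exchange leaves the result of compound 2 largely untouched, and the step from compound 2 to compound 3 is expected to be a 1.1-fold lower number from compound 2 to compound 3 (0.06 log units; within the scatter), not beyond the scatter in either direction. Compound 3 is therefore expected to give about 1500 nM in this assay, within a range of 500 nM to 5000 nM.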

Compound 3, half-maximal inhibitory concentration: 1810 nM
Beside the measured number, compound 3's estimate is 1.2-fold (0.08 log units) below it, within the range that was stated.
By their numbers in this assay, from the lowest: compounds 2 and 3 (each within the scatter of the next); then compound 1.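

In this assay, putting bromo in place of fluoro on an aromatic carbon of the six-membered aromatic ring, part of a fused or bridged system of two rings, gives a 1.1-fold higher number from compound 2 to compound 3 (0.02 log units; within the scatter). Within the data shown here, this is the first single change that can be read, and it shows that compound 2 and compound 3 cannot be told apart on this read-out, so this position accepts either of these two halogens with no measurable difference in antiproliferative activity. No data given here explain why the two halogens read alike.

Both groups are halogens. This single step says little about how far the position tolerates a different kind of group, and an amine, a methoxy group or a carboxylic acid on the same carbon could read quite differently. Also open, as far as these compounds go, is whether either halogen matters at all compared with plain hydrogen on that carbon, and whether the same exchange would read alike at another carbon of that ring.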